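Swapping a Pyridine for a Thiophene on a Shared Core

This account rests on a few compounds, and the source may have more. Where it says the series, first, only, none or still open, it means among the compounds named here.

Compound 2 `Oc1ccc(-c2cc(-c3ccncc3)nc(-c3ccc(Cl)cc3)c2)cc1` has no number in a functional assay on T47D cells (Homo sapiens) for cytotoxicity, read by CCK-8 assay and cell counting, with a stated time of 2 days; a lower number here means a stronger inhibitor, a higher number a weaker inhibitor: the record for compound 2 shows "not determined" (no result reported). The same holds for compound 1 `Oc1cccc(-c2cc(-c3ccncc3)nc(-c3ccccc3Cl)c2)c1`, where compound 1 shows "not determined" (no result reported). Only compound 3 `Oc1cccc(-c2cc(-c3ccncc3)nc(-c3ccc(Cl)cc3)c2)c1` carries a figure: in this assay compound 3 gives 3330 nM, a weak result. Compound 4 `Oc1ccc(-c2cc(-c3ccc(Cl)cc3)nc(-c3cccs3)c2)cc1` differs from compound 2 in a single place: thiophen-2-yl in place of pyridin-4-yl on an aromatic carbon. Within the data shown here, no measured pair of compounds shows a step of this kind, so its size cannot be read from the data. The expectation is that the change leaves potency roughly where compound 3 sits, within the scatter or a little weaker. Compound 4 is therefore estimated to give about 4500 nM, with a range from 1200 nM to 18000 nM.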

Compound 4, half-maximal inhibitory concentration: 6450 nM
Compound 4: middle estimate off by 1.4-fold (0.16 log units), on the low side; low and high end bracket the measured number.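

Among these compounds, no step from compound 2 to compound 4 can be read, as compound 2 has no single number. Nothing shown explains the result for compound 4. On these data alone, what thiophen-2-yl in place of pyridin-4-yl does to potency on the shared core stays open.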